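From Cyano to Chloro at the Assay Limit

This account rests on a few compounds, and the source may have more. Where it says the series, first, only, none or still open, it means among the compounds named here.

In a functional assay on NCI-H520 cells (Homo sapiens) (a higher number here means a weaker inhibitor of growth, a lower number a stronger inhibitor of growth), compound 1 (`O=S(=O)(/C=C/c1ccccc1)Cc1ccc(Nc2ncnc3ccccc23)cc1`) gives > 100000 nM, which is a limit of the assay and not a number. Compound 2 (`N#Cc1ccc(/C=C/S(=O)(=O)Cc2ccc(Nc3ncnc4ccccc34)cc2)cc1`) gives > 100000 nM, again only a limit. Compound 3 (`CC(C)(C)c1cc(/C=C/S(=O)(=O)Cc2ccc(Nc3ncnc4ccccc34)cc2)cc(C(C)(C)C)c1O`) gives 45000 nM.

Compound 4 (`O=S(=O)(/C=C/c1ccc(Cl)cc1)Cc1ccc(Nc2ncnc3ccccc23)cc1`), not yet measured, carries chloro in place of cyano on an aromatic carbon of compound 2 (chloro in place of cyano on an aromatic carbon). Among the measured compounds shown here, the one measured single change, a step that the two limits leave unreadable from compound 1 to compound 2, has no readable size because of the limit of > 100000 nM in this assay, at which 2 of the 3 values shown sit. For the measured compounds named here, no step of known size therefore carries over, and no direction can be expected with confidence.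

The expected step is a number no higher from compound 2 to compound 4 (the limit leaves the size open). For compound 4, the estimate is 100000 nM, with an expected range of 40000 nM to 200000 nM.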

Compound 4, concentration for 50% growth inhibition: 46000 nM
Compound 4: middle estimate off by 2.2-fold (0.34 log units), on the high side; the range from low to high includes it.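

Within this assay and at this aromatic carbon, chloro in place of cyano gives an at least 2.1-fold lower number from compound 2 to compound 4 (0.33 log units; beyond the scatter) and chloro in place of hydrogen gives an at least 2.1-fold lower number from compound 1 to compound 4 (0.33 log units; beyond the scatter) as well. A change at this carbon can therefore bring the number down from the assay limit, which cyano did not do. Both sizes are only lower bounds, and the step between compound 1 and compound 2 still cannot be read: the limit of > 100000 nM in this assay, at which 2 of the 4 values shown sit.

The compounds shown leave open whether chloro is special here or whether a methoxy group or an amine at this carbon would lower the number too.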